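The source may hold more compounds than are shown below. What is called first, only, known or untested is meant among the compounds shown, and "the series" means these compounds.

In a functional assay on T47D cells (Homo sapiens) for cytotoxicity, read by CCK-8 assay (a lower number here means a stronger inhibitor, a higher number a weaker inhibitor), three compounds have been measured. Compound 1, `Oc1ccccc1-c1cc(-c2ccoc2)cc(-c2ccccc2O)n1`, reaches only a limit of the assay, > 50000 nM. Compound 2, `Oc1cccc(-c2cc(-c3ccoc3)cc(-c3ccccc3O)n2)c1`, likewise reaches only a limit, > 50000 nM. Compound 3, `Oc1cccc(-c2cc(-c3cccnc3)cc(-c3ccccc3O)n2)c1`, gives a number, 6230 nM.

Compound 1 and compound 2 differ by 3-hydroxyphenyl in place of 2-hydroxyphenyl on an aromatic carbon, and the step that the two limits leave unreadable from compound 1 to compound 2. From compound 2 to compound 3 the change is pyridin-3-yl in place of furan-3-yl on an aromatic carbon, and here the step is an at least 8.0-fold lower number from compound 2 to compound 3 (0.90 log units; beyond the scatter). For the measured compounds named here, compound 3 thus carries the only number in the set, the other two values sitting at the limit of > 50000 nM in this assay, at which 2 of the 3 values shown sit. The difference between the core of compound 1 and that of compound 3 is not broken down here.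

Compound 4, `Oc1cccc(-c2cc(-c3cccnc3)cc(-c3cccc(O)c3)n2)c1`, has not been measured. It differs from compound 3 by 3-hydroxyphenyl in place of 2-hydroxyphenyl on an aromatic carbon. This is the same kind of change as that from compound 1 to compound 2, though the surroundings differ: there the place was meta to a 2-hydroxyphenyl group and meta to a furan-3-yl group, here it is meta to a 3-hydroxyphenyl group and meta to a pyridin-3-yl group. Since the earlier step, a step that the two limits leave unreadable from compound 1 to compound 2, gives no readable size, the expectation rests on compound 3 alone with its 6230 nM. The step from compound 3 to compound 4 is expected to be a 1.3-fold higher number from compound 3 to compound 4 (0.11 log units; within the scatter). Compound 4 is therefore estimated at 8000 nM, between 2000 nM and 40000 nM.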

Compound 4, half-maximal inhibitory concentration: > 50000 nM
Compound 4 was reported as a limit; the forecaster's own chance of this, stated with the estimate: 20%; middle value at least 6.2-fold (0.79 log units) from the limit.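

In this assay the change of 3-hydroxyphenyl in place of 2-hydroxyphenyl, carried onto the core that holds pyridin-3-yl, gives an at least 8.0-fold higher number from compound 3 to compound 4 (0.90 log units; beyond the scatter), so on this core the change weakens the compound by a margin beyond the scatter. The same change on the core that holds furan-3-yl, from compound 1 to compound 2, cannot be read, which leaves the new step without a second size beside it, and the series therefore does not show that the effect of the change carries from one core to another. Going by these compounds, compound 4 itself gives only a limit, > 50000 nM, so the full size of the new step stays unknown, and most of the set rests at that same end of the scale: the limit of > 50000 nM in this assay, at which 3 of the 4 values shown sit.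

For the compounds shown here, compound 3 remains the only compound with a number, so it is open which other changes to its core would keep a readable value in this assay. Also open, on these data alone, is whether an amine or a methoxy group in place of the hydroxyl on either phenyl group, or a carboxylic acid on the pyridin-3-yl group, would give a number at all.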